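Trimming the side chain of compound 2

The compounds below may be only part of what the source reports. "The series", "measured", "known", "first", "only" and "open" are said of these compounds alone.

Of the compounds shown here, three sharing one core have been measured in a functional assay on the whole organism (Tail, strain ICR) with Mus musculus as the target, in the tail flick test, with a stated time of 150 min, at a dose of 25 umol/kg by the oral route; a higher number here means a stronger effect of the compound at the dose given, a lower number a weaker effect. Compound 1 `CC(C)[C@H](NC(=O)CN(c1ncnc2c1ncn2C1CCCCO1)C1CC1)C(=O)OCc1ccccc1` gives 21.1%. Compound 2 `NC(=O)CC[C@H](NC(=O)CN(c1nc(Cl)nc2[nH]cnc12)C1CC1)C(=O)O` gives 11.4%, the lowest of the three numbers; compound 1 stands closest to it, within the scatter, and compound 3 `NC(=O)CC[C@H](NC(=O)CN(c1nc(Cl)nc2[nH]cnc12)C1CC1)C(=O)OCc1ccccc1`, which gives 31.1%, stands furthest from it. Among the compounds with values here, the one step between neighbours that differ in a single place is a number 19.7 percentage points higher from compound 2 to compound 3 (beyond the scatter).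

Compound 4 `O=C(O)CNC(=O)CN(c1nc(Cl)nc2[nH]cnc12)C1CC1` has not yet been measured. It differs from compound 2 as follows: hydrogen in place of 2-carbamoylethyl on a saturated chain carbon bound to an amide-type nitrogen and a carbonyl carbon. Compound 4 keeps the free acid of compound 2, so the measured step from compound 2 to compound 3 does not bear on it directly. Within the data shown here, the comparison of compound 1 with compound 3, both benzyl esters carrying different groups on that same chain carbon, shows values within the scatter of each other, which suggests that changes at this carbon matter little here, though these are only two compounds. Accordingly the step of a number 0.4 percentage points lower from compound 2 to compound 4 (within the scatter) is expected to stay within the scatter. Compound 4 is therefore estimated to give 11%, with a range from 0% to 25%.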

Compound 4, a percentage reported as activity, at one dose (the size of the read-out at that dose, not a potency): 9.08%
Compound 4: the middle estimate sits 1.9 percentage points above what was measured; measured number inside the range.
By their numbers in this assay, from the lowest: compounds 4, 2, 1 and 3 (each within the scatter of the next, the first and the last beyond it).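

In this assay, hydrogen in place of 2-carbamoylethyl on the saturated chain carbon bound to an amide-type nitrogen and a carbonyl carbon gives a number 2.3 percentage points lower from compound 2 to compound 4 (within the scatter) as a direct single-place reading at this carbon. The earlier compounds shown here offered no such reading, since compound 1 and compound 3 differ in more than one place. Between these two free acids, the entire 2-carbamoylethyl group can therefore be lost, leaving carboxymethyl in the cut one bond further out, without a change that stands clear of the scatter, although no measurement shown here offers an explanation for this result.

On these data alone, it remains open whether the same change would read alike on a benzyl ester, the form in which compound 3 gives 31.1%, and whether a methyl group, a longer chain or an amine on that carbon would move the number beyond the scatter. As far as these compounds go, since the read-out belongs to a single dose and time, it is also open whether compound 2 and compound 4 would remain this close under other conditions.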